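The source may report more compounds than this note shows. Statements on the series, on what has been measured and on what is new or still open speak of the compounds shown alone.

Of the compounds shown here, two have so far been measured in a functional assay on SK-N-SH cells (Homo sapiens) for inhibition, read by MTT assay; a lower number here means a stronger inhibitor, a higher number a weaker inhibitor. Compound 1 `CCCCCCCCn1cc(/C=C/C(=O)c2ccc(NC(=O)CN3CCN(c4ccccc4)CC3)cc2)nn1` gives 41400 nM in this assay. Compound 2 `COc1ccccc1N1CCN(CC(=O)Nc2ccc(C(=O)/C=C/c3cn(Cc4ccc(Br)cc4)nn3)cc2)CC1` gives 28000 nM in this assay. Compound 2 has the lower of the two numbers, but its gap to compound 1 lies within the usual scatter of repeated measurements, so on these data the two compounds cannot be told apart. Compound 3 `O=C(CN1CCN(c2ccccc2)CC1)Nc1ccc(C(=O)/C=C/c2cn(Cc3ccc(Br)cc3)nn2)cc1` has not yet been measured. It differs from compound 2 in one place: hydrogen in place of methoxy on an aromatic carbon. Within the data shown here, no two measured compounds differ from each other in just one place, so there is no measured step that shows what such a change does. The expectation for compound 3 therefore rests on compound 2 giving 28000 nM and on the change being a small one. The expected step is a 1.3-fold higher number from compound 2 to compound 3 (0.10 log units; within the scatter), which is no larger than the scatter in either direction. Compound 3 is estimated at 35000 nM in this assay, with a likely range from 12000 nM to 100000 nM.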

Compound 3, half-maximal inhibitory concentration: 72400 nM
For compound 3 the middle estimate is 2.1-fold (0.32 log units) below the measured one; the range from low to high includes it.
By their numbers in this assay, from the lowest: compounds 2, 1 and 3 (each within the scatter of the next, the first and the last beyond it).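

The step from the 2-methoxyphenyl compound to the phenyl compound, a 2.6-fold higher number from compound 2 to compound 3 (0.41 log units; beyond the scatter), gives the series its first measured one-place change in this assay, and it shows that the methoxy on this aromatic carbon, ortho to a large group, counts for something: without it the compound is a modestly weaker inhibitor. The other new step, a 1.7-fold higher number from compound 1 to compound 3 (0.24 log units; within the scatter), replaces heptyl with 4-bromophenyl on a saturated chain carbon bound to an aromatic nitrogen, and on this pair these two quite different groups cannot be told apart. No measured property of these compounds offers an explanation for the methoxy step.

The compounds shown leave open whether a hydroxyl group, a chlorine atom or a longer ethoxy group on that aromatic carbon would behave like the methoxy or like the hydrogen. Among these compounds, they also leave open whether the methoxy gives a step of similar size when heptyl rather than 4-bromophenyl sits at the other end of the molecule, as only one such pair can be read here.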